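The source may hold more compounds than are shown below. What is called first, only, known or untested is meant among the compounds shown, and "the series" means these compounds.

Measured compounds:
compound 1 `Fc1ccc(C2=CC3CNCC(C2)C3)cn1`, 85 nM
compound 2 `CN1CC2C=C(c3ccc(F)nc3)CC(C2)C1`, > 10000 nM
compound 3 `CC(C)Oc1cncc(C2=CC3CNCC(C2)C3)c1`, 164 nM

In an in vitro functional assay on SH-EP1 cells for agonist activity at Neuronal acetylcholine receptor; alpha4/beta2 (Homo sapiens), read by FLIPR and calcium flux (on this read-out higher numbers stand for an effect only at larger amounts of compound and lower numbers for an effect already at smaller amounts), compound 1 gives 85 nM. For compound 2 this assay reports only a limit, > 10000 nM. The step of an at least 110-fold higher number from compound 1 to compound 2 (2.07 log units; beyond the scatter) is methyl in place of hydrogen on an amine nitrogen in a ring; the step is defined only by the limit, (the limit of > 10000 nM in this assay, at which 1 of the 3 values shown sits). Compound 3 gives 164 nM; the difference between the cores of compound 1 and compound 3 is not broken down here, and the two values lie within the scatter.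

Compound 4 `CC(C)Oc1cncc(C2=CC3CC(C2)CN(C)C3)c1` is the same kind of change applied to compound 3: methyl in place of hydrogen on an amine nitrogen in a ring. Given the step of an at least 110-fold higher number from compound 1 to compound 2 (2.07 log units; beyond the scatter) from compound 1 to compound 2, compound 4 is expected to give a step of a 91-fold higher number from compound 3 to compound 4 (1.96 log units; beyond the scatter) in this assay, most likely ending at a limit. Compound 4 is estimated at 15000 nM, between 3000 nM and 60000 nM.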

Compound 4, half-maximal effective concentration: > 10000 nM
Compound 4 ended at the assay's limit (the forecaster's own chance of this, stated with the estimate: 75%); the middle value is on the limit's open side.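

In this assay, methyl in place of hydrogen on an amine nitrogen in a ring again gives a large step, an at least 60-fold higher number from compound 3 to compound 4 (1.78 log units; beyond the scatter). Compound 4 gives > 10000 nM, which is a limit of the assay and not a number, so this step has no upper bound. The change goes the same way on the core of compound 1 and the core of compound 3, but its true size on either core remains unknown, and the two sizes cannot be compared: the same change on two cores in this assay, an at least 110-fold higher number (2.07 log units; beyond the scatter) from compound 1 to compound 2 and an at least 60-fold higher number (1.78 log units; beyond the scatter) from compound 3 to compound 4; the limit leaves it open whether they differ

The compounds shown leave open how an ethyl group or a longer chain on that ring nitrogen would read out. They also leave open whether the step holds on any other core.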